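A Pyrrolidine Amide Weighed Against Two Limits

The compounds below may be only part of what the source reports. "The series", "measured", "known", "first", "only" and "open" are said of these compounds alone.

Measured so far:
compound 1 `Cc1c(C(C)C)c(=O)on1C(=O)NC(C)(C)C`: > 1000 nM
compound 2 `Cc1c(C(C)C)c(=O)on1C(=O)N(C)CC(N)=O`: > 1000 nM

Of the compounds shown here, two of the shared core have been measured in an assay (strain Wistar) for inhibition of Hormone-sensitive lipase (Rattus norvegicus), read by spectrophotometry; a lower number here means a stronger inhibitor, a higher number a weaker inhibitor. Compound 1 gives > 1000 nM, which is a limit of the assay and not a number. Compound 2 gives > 1000 nM in this assay, again a limit rather than a number. Among the compounds with values here, the single measured step is a step that the two limits leave unreadable from compound 1 to compound 2; both values sit at the limit of > 1000 nM in this assay, at which 2 of the 2 values shown sit, so neither its direction nor its size can be read.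

Compound 3 `Cc1c(C(C)C)c(=O)on1C(=O)N1CCCC1` differs from compound 2 by pyrrolidin-1-yl in place of (carbamoylmethyl)(methyl)amino on a carbonyl carbon. Within the data shown here, no measured step bears on this change, since the only step known is unreadable. What remains is that compound 2 stands at the limit, with no number beneath it. In this assay no step beyond the scatter can therefore be expected in either direction, and the estimated step is a step that the limit leaves unreadable from compound 2 to compound 3. Compound 3 is expected to give 1500 nM, within 300 nM to 8000 nM, and most likely the assay will again report only a limit.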

Compound 3, half-maximal inhibitory concentration: 15 nM
Compound 3: the middle estimate sits 100-fold (2.00 log units) above what was measured; the measured number lies below the stated range.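

Within the data shown here, the position on the carbonyl carbon had so far given no number, only limits of the assay: the limit of > 1000 nM in this assay, at which 2 of the 3 values shown sit.

With pyrrolidin-1-yl in this place, the series gains its first readable value in this assay, and the change proves large: the result is an at least 66-fold lower number from compound 2 to compound 3 (1.82 log units; beyond the scatter) with pyrrolidin-1-yl in place of (carbamoylmethyl)(methyl)amino, and an at least 66-fold lower number from compound 1 to compound 3 (1.82 log units; beyond the scatter) with pyrrolidin-1-yl in place of (tert-butyl)amino. Among these compounds, the group on this carbonyl carbon can therefore move the number far beyond the scatter, which the two earlier compounds, both held at a limit, could not show; among the three compounds, the one carrying the five-membered ring is the only one with a readable value.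

From the compounds shown here alone, whether this holds for other rings or amines in the same place, such as piperidine, morpholine or an open-chain diethylamino group, remains open. Also open, going by these compounds, are the true sizes of both steps, which are bounded by limits on one side, and whether the substituents elsewhere on the shared core can be changed with the pyrrolidin-1-yl group in place.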